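Aryl replacement on the shared core: toward compound 4

The source may hold more compounds than are shown below. What is called first, only, known or untested is meant among the compounds shown, and "the series" means these compounds.

Measured compounds:
compound 1 `O=C(O)c1csc(-n2nc(-c3ccccc3)c3cccnc32)n1` — 200 nM
compound 2 `COc1ccc(-c2nn(-c3nc(C(=O)O)cs3)c3ccccc23)cc1` — 4 nM
compound 3 `O=C(O)c1csc(-n2nc(-c3ccc(C(F)(F)F)cc3)c3ccccc32)n1` — 140 nM

In an assay on isolated protein for antagonist activity at prostaglandin E2 receptor EP1 subtype (Homo sapiens), read by reporter gene assay (a lower number here means a stronger inhibitor, a higher number a weaker inhibitor), compound 2 stands at the lowest of the three numbers with 4 nM. Compound 3 gives 140 nM, and compound 1 gives 200 nM, both well above compound 2. For the measured compounds named here, the one single-point step within the set, a 35-fold higher number from compound 2 to compound 3 (1.54 log units; beyond the scatter), is large and goes toward weaker inhibition. Going by the values given here, no step is computed between compound 1 and compound 2; their values simply show compound 1 at the higher number.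

Compound 4 `O=C(O)c1csc(-n2nc(-c3cncnc3)c3ccccc32)n1` differs from compound 2 by pyrimidin-5-yl in place of 4-methoxyphenyl on an aromatic carbon. The step from compound 2 to compound 3 bears on this, since the methoxy group is given up in both cases, and that step was large. The change to compound 4 is not the same change, so a smaller shift is not ruled out, but the direction expected is toward a higher number, as a 20-fold higher number from compound 2 to compound 4 (1.30 log units; beyond the scatter). Compound 4 is therefore estimated at 80 nM, with a range of 20 nM to 320 nM, in this assay.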

Compound 4, half-maximal inhibitory concentration: > 100 nM
Compound 4: no number, only a limit (the forecaster's own chance of this, stated with the estimate: 5%); middle value at least 1.2-fold (0.09 log units) from the limit.
By their numbers in this assay, from the lowest: compound 2; then compounds 3 and 1 (each within the scatter of the next).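

In this assay, pyrimidin-5-yl in place of 4-methoxyphenyl gives an at least 25-fold higher number from compound 2 to compound 4 (1.39 log units; beyond the scatter), so the loss at this position extends beyond the swap of methoxy for trifluoromethyl to replacement of the whole aryl ring. For the compounds shown here, both replacements of 4-methoxyphenyl on the shared core now lead to higher numbers, and compound 2 remains the only member of this pair of steps with a low nanomolar value. The value for compound 4 is a limit, not a number: the limit of > 100 nM in this assay, at which 1 of the 4 values shown sits.

How far compound 4 lies from compound 3 cannot be read from that limit. Also open, on these data alone, is whether the step follows from the loss of the methoxy group or the change of ring, which a methoxy group on the pyrimidin-5-yl ring, or a 4-ethoxyphenyl or 4-hydroxyphenyl group, would help separate.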